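Permeability notes: isopentyl for cyclohexyl on the core

A few compounds are considered here, and "the series" means these few. Any claim that something is new, unique, unknown or untested is made for them only; others in the source may bear on it.

Compound 3 `COc1ccc(F)cc1CNCCCNc1ccnc2cc(C3CCCCC3)ccc12` gives 23 10^-6 cm/s in an ADME assay for permeability, using PAMPA, with a stated time of 30 min, at pH 7.4; a higher number here means that the compound crosses the layer faster, a lower number that the compound crosses the layer more slowly. Compound 2 `COc1ccc(F)cc1CNCCCNc1ccnc2cc(Cc3cc(C)cc(C)c3)ccc12` gives 23 10^-6 cm/s in this assay, and no change at the digits printed from compound 2 to compound 3 (within the scatter); together these two compounds give the lowest numbers of the three measured. Compound 1 `COc1ccc(Oc2ccc3c(NCCCNCc4cc(F)ccc4OC)ccnc3c2)cc1` gives 317 10^-6 cm/s in this assay and sits furthest from compound 3, with a 14-fold lower number from compound 1 to compound 3 (1.14 log units; beyond the scatter) and, for the parallel change, a 14-fold lower number from compound 1 to compound 2 (1.14 log units; beyond the scatter).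

Compound 4 `COc1ccc(F)cc1CNCCCNc1ccnc2cc(CCC(C)C)ccc12` differs from compound 3 in one place: isopentyl in place of cyclohexyl on an aromatic carbon. Of the measured steps, the one that bears most directly on this change is the swap of one hydrocarbon group for another on the same aromatic carbon, where no change at the digits printed from compound 2 to compound 3 (within the scatter). The two large steps from compound 1 both removed the 4-methoxyphenoxy group and are not of the same kind, so they carry less weight here. For compound 4 the expectation is therefore no change at the digits printed from compound 3 to compound 4 (within the scatter), a step within the scatter. Compound 4 is estimated at 23 10^-6 cm/s in this assay, with a range from 11 10^-6 cm/s to 48 10^-6 cm/s.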

Compound 4, apparent permeability: 23 10^-6 cm/s
Beside the measured number, compound 4's estimate shows no gap at the digits printed; low and high end bracket the measured number.
By their numbers in this assay, from the lowest: compounds 2, 3 and 4 (each within the scatter of the next); then compound 1.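

In this assay isopentyl in place of cyclohexyl gives no change at the digits printed from compound 3 to compound 4 (within the scatter) on this aromatic carbon, so an open chain reads level with the six-membered non-aromatic ring here. Isobutyl in place of 3,5-dimethylphenyl on the saturated chain carbon gives no change at the digits printed from compound 2 to compound 4 (within the scatter) as well, which extends that level reading to a substituent without an aromatic ring. Isopentyl in place of 4-methoxyphenoxy gives a 14-fold lower number from compound 1 to compound 4 (1.14 log units; beyond the scatter) and matches the two earlier steps from compound 1, so of the four compounds only compound 1 stands apart.

From the compounds shown here alone, whether the high number of compound 1 belongs to the whole 4-methoxyphenoxy group or to its ether oxygen stays open, as does the outcome for an amine or a carboxylic acid on this aromatic carbon. No evidence at hand explains why these three groups read alike.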